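A few compounds are considered here, and "the series" means these few. Any claim that something is new, unique, unknown or untested is made for them only; others in the source may bear on it.

Within the data shown here, in a functional assay on the whole organism (strain Wistar) for inhibition, with Rattus norvegicus as the target, read by paw edema, with a stated time of 24 h, at a dose of 100 mg/kg (on this read-out higher numbers stand for more inhibition at the one dose given (going by the name of the read-out) and lower numbers for less inhibition), compound 2 `COc1cc2c(cc1OC)C(CC(=O)Nc1ccccc1C)CC2` gives 23.3%, the lower of the two numbers measured so far. Among the measured compounds shown here, the only neighbour is compound 1 `COc1cc2c(cc1OC)C(CC(=O)Nc1ccccc1)CC2`, which in this assay gives 30%; the step of a number 6.7 percentage points lower from compound 1 to compound 2 (within the scatter) is a change too small to separate the two compounds.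

Compound 3 `COc1cc2c(cc1OC)C(CC(=O)Nc1cccc(C)c1)CC2` has not been measured. It differs from compound 2 in a single place: 3-methylphenyl in place of 2-methylphenyl on an amide-type nitrogen. The two compounds are built from the same atoms, joined differently, so the methyl group simply sits at another point of the ring on the amide-type nitrogen.

For the measured compounds named here, only one measured step bears on this, and only loosely: putting a methyl onto the aromatic ring moved the number by a number 6.7 percentage points lower from compound 1 to compound 2 (within the scatter), within the scatter. Moving that methyl to another position is a smaller kind of change than adding it, so no step beyond the scatter is expected from compound 2 to compound 3, that is a number 2.7 percentage points higher from compound 2 to compound 3 (within the scatter).

For compound 3 the expected inhibition is 26%, with a range from 12% to 40%.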

Compound 3, a percentage reported as inhibition, in the whole organism at one dose (the size of the read-out at that dose, not a potency): 41.7%
Compound 3: middle estimate off by 15.7 percentage points, on the low side; the whole stated range lies below it.
By their numbers in this assay, from the lowest: compounds 2 and 1 (each within the scatter of the next); then compound 3.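

In this assay, the point of attachment of the methyl group on this ring makes a real difference: 3-methylphenyl in place of 2-methylphenyl gives a number 18.4 percentage points higher from compound 2 to compound 3 (beyond the scatter) even though the two compounds are built from the same atoms. Compound 3 also stands apart from the plain phenyl compound, with a number 11.7 percentage points higher from compound 1 to compound 3 (beyond the scatter) for the methyl in place of hydrogen, whereas compound 2 could not be separated from compound 1. Adding a methyl to this ring therefore has no single outcome in these three compounds, and only the 3-methylphenyl compound is set apart from the other two. No measurement available here explains why the two placements differ.

The compounds shown leave open whether this gain belongs to the methyl group itself, since a chlorine or a methoxy group at the same point of the ring could give a similar number or a very different one. From the compounds shown here alone, they also offer a single dose and a single time point, so how compound 3 behaves at other doses or times remains unknown.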